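The source may hold more compounds than are shown below. What is called first, only, known or untested is meant among the compounds shown, and "the series" means these compounds.

Notes on the shared core. Compound 1 `C#CCN(c1nc(-c2cccc([N+](=O)[O-])c2)no1)C1CCCCC1` gives 45.5 ug/mL in an ADME assay on HepG2 cells (Homo sapiens) for cytotoxicity, read by MTT assay, with a stated time of 48 h; a lower number here means that less compound is tolerated, a higher number that more compound is tolerated. Compound 3 `C#CCN(c1nc(-c2ccccc2)no1)C1CCCCC1` gives 109 ug/mL in this assay, so that a 2.4-fold higher number from compound 1 to compound 3 (0.38 log units; beyond the scatter). Compound 2 `CC(=O)OC[C@H]1O[C@H](OC[C@@H](Cn2cc(CN(c3nc(-c4cccc([N+](=O)[O-])c4)no3)C3CCCCC3)nn2)OC(C)=O)C=C[C@@H]1OC(C)=O` reaches only a limit in this assay, > 200 ug/mL, which places it at the limit of > 200 ug/mL in this assay, at which 1 of the 3 values shown sits. Where compound 2 stands among the numbers is therefore told only as a limit. Compound 4 `CC(=O)OC[C@H]1O[C@H](OC[C@@H](Cn2cc(CN(c3nc(-c4ccc(Br)cc4)no3)C3CCCCC3)nn2)OC(C)=O)C=C[C@@H]1OC(C)=O` differs from compound 2 by 4-bromophenyl in place of 3-nitrophenyl on an aromatic carbon. The single measured step bearing on this change is a 2.4-fold higher number from compound 1 to compound 3 (0.38 log units; beyond the scatter), where the nitro leaves; here it leaves too, while a bromine enters, for which no step is shown. An upward step of about that size, or none beyond the scatter, is expected in this assay. Compound 4 is estimated at 220 ug/mL, within 100 ug/mL to 450 ug/mL, and a limit is again expected. The expected step is a step that the limit leaves unreadable from compound 2 to compound 4.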

Compound 4, half-maximal cytotoxic concentration: 47.6 ug/mL
The estimate for compound 4 lay 4.6-fold (0.66 log units) above the measured number; measured number below the stated range.
By their numbers in this assay, from the lowest: compounds 1 and 4 (each within the scatter of the next); then compound 3. At a limit, above all of these: compound 2.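

At this place, 4-bromophenyl in place of 3-nitrophenyl gives an at least 4.2-fold lower number from compound 2 to compound 4 (0.62 log units; beyond the scatter) in this assay. This runs opposite to a 2.4-fold higher number from compound 1 to compound 3 (0.38 log units; beyond the scatter), so the upward step seen when the nitro group alone leaves does not carry over to a change that also brings in bromine. Compound 2 stands at a limit, so this step is a minimum: the limit of > 200 ug/mL in this assay, at which 1 of the 4 values shown sits.

Going by these compounds, whether the lower number goes with the bromine itself or with its place on the phenyl ring stays open. On these data alone, how an amine or a methoxy group on that phenyl ring would stand is also open.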